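Amino for Methoxy: Three Measured Compounds, One Expectation

A few compounds are considered here, and "the series" means these few. Any claim that something is new, unique, unknown or untested is made for them only; others in the source may bear on it.

Compound 1 `O=[N+]([O-])c1cccc(-c2cc(-c3ccccc3)n[nH]2)c1` gives 11400 nM in a functional assay on AGS cells (Homo sapiens) for inhibition, read by MTT assay, with a stated time of 48 h; a higher number here means a weaker inhibitor of growth, a lower number a stronger inhibitor of growth.
Compound 2 `COc1ccc(-c2cc(-c3ccc4ccccc4c3)n[nH]2)cc1` gives 19000 nM in this assay.
Compound 3 `COc1ccc(-c2cc(-c3ccccc3-c3ccccc3)n[nH]2)cc1` gives 790 nM in this assay.

Among these three numbers, compound 3 has the lowest value, and its gaps to compound 1 and compound 2 both lie beyond the usual scatter of repeated measurements. So compound 3 is the strongest growth inhibitor of the three in this assay.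

Compound 4 `Nc1ccc(-c2cc(-c3ccccc3-c3ccccc3)n[nH]2)cc1` differs from compound 3 in one place: amino in place of methoxy on an aromatic carbon. Among the compounds with values here, no pair of measured compounds shows this same change, so there is no measured step to lean on; the three values above cover other changes only. Without such a guide, the expectation is for a small step from compound 3 to compound 4 in this assay, more likely toward a somewhat weaker inhibitor than a stronger one, but possibly none beyond the scatter: the step estimated here is a 1.8-fold higher number from compound 3 to compound 4 (0.25 log units; within the scatter). Compound 4 is therefore expected to give about 1400 nM, with a range from 250 nM to 8000 nM.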

Compound 4, concentration for 50% growth inhibition: 8400 nM
The estimate for compound 4 lay 6.0-fold (0.78 log units) below the measured number; measured number outside the range, above it.
By their numbers in this assay, from the lowest: compound 3; then compounds 4, 1 and 2 (each within the scatter of the next, the first and the last beyond it).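

In this assay, the change from 4-methoxyphenyl to 4-aminophenyl gives an 11-fold higher number from compound 3 to compound 4 (1.03 log units; beyond the scatter) with the rest of the molecule unchanged. Within the data shown here, this is the first one-place comparison in the set, and it shows that the group on this aromatic carbon, para to a large group, can by itself move the number far beyond the scatter. Here methoxy gives the stronger growth inhibitor of the pair, but nothing available explains the difference between these two groups.

Going by these compounds, whether a hydroxyl group, a dimethylamino group or a fluorine atom at this position would stay close to compound 3 or fall nearer compound 4 remains open. So does whether the same change would have a similar effect in compound 2, which also carries a 4-methoxyphenyl group on a different core.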